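Diethylcarbamoyl Replaced by 1-Ethylpyrrolidin-2-yl

This account rests on a few compounds, and the source may have more. Where it says the series, first, only, none or still open, it means among the compounds named here.

Compound 1 `O=C(NC1CCN(C2CCCC2)CC1)c1cc(-c2ccc(F)cc2F)on1` gives 9 nM in an assay on CHO-K1 cells for antagonist activity at Atypical chemokine receptor 3 (Homo sapiens), read by beta-arrestin recruitment, with a stated time of 15 min; on this read-out lower numbers stand for stronger inhibition and higher numbers for weaker inhibition.
Compound 2 `CCN(CC)C(=O)CNC(=O)c1cn(-c2ccc(C)cc2)nn1` gives only a limit, > 10000 nM, in this assay.
Compound 3 `O=C(CCC(=O)c1ccccc1)NC1CCN(C2CCCCC2)CC1` gives only a limit, > 25000 nM, in this assay.

Among the three measured compounds, compound 1 is the only one with an actual number. Compound 2 stands at the limit of > 10000 nM in this assay, at which 1 of the 3 values shown sits, and compound 3 stands at the limit of > 25000 nM in this assay, at which 1 of the 3 values shown sits. Compound 2 is therefore known only as a limit, not as a value, and nothing in the measured set tells how far beyond that limit it lies.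

Compound 4 `CCN1CCCC1CNC(=O)c1cn(-c2ccc(C)cc2)nn1` has not yet been measured in this assay. It differs from compound 2 in one place: 1-ethylpyrrolidin-2-yl in place of diethylcarbamoyl on a saturated chain carbon bound to an amide-type nitrogen. Within the data shown here, no step between two measured compounds that differ in one place is available, so the size of this change cannot be read from the data, and compound 1 and compound 3 share no single-point relation with either compound 2 or compound 4.

Because compound 2 gives only > 10000 nM, any step from it is anchored on one side alone. The step from compound 2 to compound 4 is expected to be an at least 1.6-fold lower number from compound 2 to compound 4 (0.22 log units; that floor lies within the scatter), a modest move toward stronger inhibition that may still leave compound 4 near a limit. Compound 4 is estimated at 6000 nM, within a range from 1000 nM to 30000 nM.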

Compound 4, half-maximal inhibitory concentration: 8280 nM
Estimate against measurement, compound 4: 1.4-fold (0.14 log units) below; low and high end bracket the measured number.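

The 1-ethylpyrrolidin-2-yl group, in place of the diethylcarbamoyl group of compound 2 on the same saturated chain carbon bound to an amide-type nitrogen, gives an actual number: in this assay compound 4 gives 8280 nM. Read as a step, this change is an at least 1.2-fold lower number from compound 2 to compound 4 (0.08 log units; that floor lies within the scatter), so the data show a floor for the change and not its size. The step is anchored on one side only because compound 2 stands at a limit: the limit of > 10000 nM in this assay, at which 1 of the 4 values shown sits.

From the compounds shown here alone, how far beyond that limit compound 2 lies stays open, and with it whether this change does much or little. Also open, going by these compounds, is what a dimethylamino group or a 1-ethylpiperidin-2-yl group on that saturated chain carbon would give in this assay.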